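Swapping the Chloropropyl Tail for tert-Butyl on the Alkyne

A few compounds are considered here, and "the series" means these few. Any claim that something is new, unique, unknown or untested is made for them only; others in the source may bear on it.

Compound 3 `O=c1[nH]c(=O)n(CCC(CO)CO)cc1C#CCCCCl` carries a 5-chloropent-1-yn-1-yl group on the shared core. In a functional assay on SW-620 cells (Homo sapiens) for antiproliferative activity, read by MTT assay, with a stated time of 72 h (a higher number here means a weaker inhibitor, a lower number a stronger inhibitor), compound 3 gives only a limit, > 100000 nM. Compound 1 `O=c1[nH]c(=O)n(CCC(CO)CO)cc1-c1ccco1` also reaches only a limit in this assay, > 100000 nM. Compound 2 `O=c1[nH]c(=O)n(CCC(CO)CO)cc1C#CCc1ccccc1` gives 72400 nM in this assay. The step that the two limits leave unreadable from compound 1 to compound 3 cannot be read between two limits, and the step of an at least 1.3-fold higher number from compound 2 to compound 3 (0.14 log units; that floor lies within the scatter) has a floor within the scatter; the limit of > 100000 nM in this assay, at which 2 of the 3 values shown sit, shows how little the numbers separate. Compound 4 `CC(C)(C)C#Cc1cn(CCC(CO)CO)c(=O)[nH]c1=O` differs by tert-butyl in place of 3-chloropropyl on a triple-bonded carbon. For the measured compounds named here, no measured step touches a tert-butyl group, so no direction beyond the scatter is expected. The step from compound 3 to compound 4 is estimated as a step that the limit leaves unreadable from compound 3 to compound 4. Compound 4 is therefore expected to stay near the limit, at an estimated 150000 nM between 50000 nM and 500000 nM.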

Compound 4, half-maximal inhibitory concentration: > 100000 nM
Compound 4: only a limit was reported (the forecaster's own chance of this, stated with the estimate: 70%); the middle value lies beyond the limit too.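

With tert-butyl on the triple-bonded carbon, a tail holding carbon alone also gives no readable value in this assay, so the chlorine of compound 3 is not required for a compound to sit at this limit. The steps from compound 1 and from compound 3 to compound 4 cannot be read, and the remaining step, an at least 1.3-fold higher number from compound 2 to compound 4 (0.14 log units; that floor lies within the scatter), does not separate the two compounds. The values now crowd at one limit: the limit of > 100000 nM in this assay, at which 3 of the 4 values shown sit.

Going by these compounds, it remains open whether an amine or a carboxylic acid in place of tert-butyl on a triple-bonded carbon would give a value clear of that limit.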